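Aroyl in Place of Aryl on a Shared Hydrazide Core

The source may report more compounds than this note shows. Statements on the series, on what has been measured and on what is new or still open speak of the compounds shown alone.

Compound 1 `O=C(NNc1ccccc1F)c1ccc(NS(=O)(=O)c2cnc(O)nc2O)cc1` gives 11700 nM in a functional assay on A549 cells (Homo sapiens) for antiproliferative activity, read by MTT assay, with a stated time of 24 h; a higher number here means a weaker inhibitor, a lower number a stronger inhibitor. Compound 3 `Cc1ccccc1C(=O)NNC(=O)c1ccc(NS(=O)(=O)c2cnc(O)nc2O)cc1` gives 15100 nM in this assay, and the step of a 1.3-fold higher number from compound 1 to compound 3 (0.11 log units; within the scatter) shows what putting a carbonyl-bearing aromatic group in place of a plain aromatic group on the amine nitrogen did to the number. Compound 2 `Cc1ccccc1NNC(=O)c1cccc(NS(=O)(=O)c2cnc(O)nc2O)c1` gives 14200 nM in this assay, which places it second highest of the three numbers; its nearest neighbour is compound 3 and its furthest is compound 1, and both of those gaps lie within the scatter. Compound 4 `O=C(NNC(=O)c1cccc(NS(=O)(=O)c2cnc(O)nc2O)c1)c1cccc(Cl)c1` has not yet been measured in this assay. It differs from compound 2 in one place: (3-chlorophenyl)carbonyl in place of 2-methylphenyl on an amine nitrogen. This is the same kind of exchange that separates compound 1 from compound 3, and that step stayed within the scatter, so no movement beyond the scatter is expected here either. The expected step is a 1.0-fold lower number from compound 2 to compound 4 (0.01 log units; within the scatter). Compound 4 is expected to give 14000 nM, with a range from 7000 nM to 28000 nM.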

Compound 4, half-maximal inhibitory concentration: 6000 nM
Beside the measured number, compound 4's estimate is 2.3-fold (0.37 log units) above it, and the stated range ends above it.
By their numbers in this assay, from the lowest: compounds 4, 1, 2 and 3 (each within the scatter of the next, the first and the last beyond it).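

In this assay, (3-chlorophenyl)carbonyl in place of 2-methylphenyl on an amine nitrogen gives a 2.4-fold lower number from compound 2 to compound 4 (0.37 log units; beyond the scatter), showing that a change at this position can move the number beyond the scatter. The earlier exchange of 2-fluorophenyl for (2-methylphenyl)carbonyl at this position gave a 1.3-fold higher number from compound 1 to compound 3 (0.11 log units; within the scatter), so a carbonyl-bearing group in place of a plain aromatic group does not by itself ensure such a shift, although the two pairs also differ in their cores and substituents. Nothing shown here explains the larger step.

The compounds shown leave open whether the carbonyl or the chlorine accounts for the step, as both enter together. They also leave open whether a bromine, a methoxy group or an amine in place of that chlorine would move the number further.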